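The source may hold more compounds than are shown below. What is called first, only, known or untested is meant among the compounds shown, and "the series" means these compounds.

Of the compounds shown here, three that share a core have been tested in an ADME assay on RAW264.7 cells (Mus musculus) for cytotoxicity, read by MTT assay, with a stated time of 48 h; a higher number here means a weaker inhibitor, a lower number a stronger inhibitor. Compound 1, `Cc1cc(NC(=O)c2ccc(C#N)cc2)ccc1NS(C)(=O)=O`, gives 171000 nM. Compound 2, `Cc1cc(NC(=O)c2cccc(C(F)(F)F)c2)ccc1NS(C)(=O)=O`, gives 110000 nM, and these two values sit within the usual scatter of each other. The difference between the cores of compound 1 and compound 2 is not broken down here. Compound 3, `COc1cc(NC(=O)c2ccc(C#N)cc2)ccc1NS(C)(=O)=O`, reaches the limit of the assay, > 250000 nM, which is a limit rather than a number.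

Compound 3 is made from compound 1 by a single change, (methoxy in place of methyl on an aromatic carbon). This change produced an at least 1.4-fold higher number from compound 1 to compound 3 (0.16 log units; that floor lies within the scatter), and the floor of that step is set by the limit of > 250000 nM in this assay, at which 1 of the 3 values shown sits, so the true size of the step is not known.

Compound 4, `COc1cc(NC(=O)c2cccc(C(F)(F)F)c2)ccc1NS(C)(=O)=O`, is not yet measured. It arises from compound 2 by the same change, (methoxy in place of methyl on an aromatic carbon), at a place described in the same words as before. For compound 4 the expected step in this assay is a 1.8-fold higher number from compound 2 to compound 4 (0.26 log units; within the scatter), because the same change once gave an at least 1.4-fold higher number from compound 1 to compound 3 (0.16 log units; that floor lies within the scatter). Compound 2 starts at 110000 nM, and the expectation for compound 4 is built from that starting point. Compound 4 is therefore estimated to give about 200000 nM, with a likely range from 100000 nM to 400000 nM.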

Compound 4, half-maximal inhibitory concentration: 84800 nM
Compound 4: the middle estimate sits 2.4-fold (0.37 log units) above what was measured; the whole stated range lies above it.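

Placed on a second core in this assay, methoxy in place of methyl gave a 1.3-fold lower number from compound 2 to compound 4 (0.11 log units; within the scatter), so this step alone cannot be told apart from ordinary variation between repeated measurements. Setting this step beside the earlier one shows that neither step is established as a real shift, and it does not show whether the change acts alike or differently on the two cores: the same change on two cores in this assay, an at least 1.4-fold higher number (0.16 log units; that floor lies within the scatter) from compound 1 to compound 3 and a 1.3-fold lower number (0.11 log units; within the scatter) from compound 2 to compound 4; the limit leaves it open whether they differ. On these data alone, compound 3 carries a limit rather than a number, so the size of the earlier step remains unknown and this series offers no firm basis yet for carrying the change from one core to another: the limit of > 250000 nM in this assay, at which 1 of the 4 values shown sits.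

The compounds shown leave open what other groups would do on the same aromatic carbon, for example an amine or a longer chain such as ethoxy in place of the methyl or methoxy. They also leave open how the change would behave on a core that carries a carboxylic acid where these compounds have the nitrile or the trifluoromethyl, and whether a third core would give a step that can be read beyond the scatter.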